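Fluoro in place of hydrogen on the ethylamide analogue

The source may report more compounds than this note shows. Statements on the series, on what has been measured and on what is new or still open speak of the compounds shown alone.

Compound 3 `CCNC(=O)c1cc(Oc2ccc(NC(=O)c3cc4cccnc4n(-c4ccccc4)c3=O)cc2)ccn1` gives 1120 nM in a functional assay on NCI-H460 cells (Homo sapiens) for antiproliferative activity, read by MTT assay, with a stated time of 72 h; a higher number here means a weaker inhibitor, a lower number a stronger inhibitor. Among the three numbers measured, it is set apart only from compound 1 `CNC(=O)c1cc(Oc2ccc(NC(=O)c3cc4cccnc4n(-c4ccccc4)c3=O)cc2)ccn1`, which gives 320 nM, by the step of a 3.5-fold higher number from compound 1 to compound 3 (0.54 log units; beyond the scatter); against compound 2 `CNC(=O)c1cc(Oc2ccc(NC(=O)c3cc4cccnc4n(-c4ccccc4F)c3=O)cc2)ccn1`, which gives 590 nM, the two values lie within the scatter of each other. Compound 4 `CCNC(=O)c1cc(Oc2ccc(NC(=O)c3cc4cccnc4n(-c4ccccc4F)c3=O)cc2)ccn1` differs from compound 3 by fluoro in place of hydrogen on an aromatic carbon. For the measured compounds named here, the one measured step that bears on this change is a 1.8-fold higher number from compound 1 to compound 2 (0.27 log units; within the scatter), a rise too small to count. Compound 4 is therefore expected to show a similarly small rise or none, a 1.6-fold higher number from compound 3 to compound 4 (0.21 log units; within the scatter), with an estimated 1800 nM in this assay and a range from 800 nM to 4000 nM.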

Compound 4, half-maximal inhibitory concentration: 1230 nM
Beside the measured number, compound 4's estimate is 1.5-fold (0.17 log units) above it; measured number inside the range.
By their numbers in this assay, from the lowest: compounds 1, 2, 3 and 4 (each within the scatter of the next, the first and the last beyond it).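

Phenyl to 2-fluorophenyl on the ethylamide gives a 1.1-fold higher number from compound 3 to compound 4 (0.04 log units; within the scatter), so this change now stays within the scatter on both amides, and the two readings agree: the same change on two cores in this assay, a 1.8-fold higher number (0.27 log units; within the scatter) from compound 1 to compound 2 and a 1.1-fold higher number (0.04 log units; within the scatter) from compound 3 to compound 4, 1.7-fold (0.23 log units) apart, within the scatter of two such steps

The methyl in place of hydrogen on the amide chain, first read only on the phenyl core, also holds on the 2-fluorophenyl core, with a 2.1-fold higher number from compound 2 to compound 4 (0.32 log units; beyond the scatter), so the modest rise from methylamide to ethylamide is seen twice: the same change on two cores in this assay, a 3.5-fold higher number (0.54 log units; beyond the scatter) from compound 1 to compound 3 and a 2.1-fold higher number (0.32 log units; beyond the scatter) from compound 2 to compound 4, 1.7-fold (0.23 log units) apart, within the scatter of two such steps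

Open, going by these compounds, is whether a chloro or methoxy group on that aromatic carbon would also stay within the scatter. Also open, on these data alone, is how a propyl chain or a cyclopropyl group on the amide nitrogen would read.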